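Opening the piperidin-1-yl ring of compound 2

This account rests on a few compounds, and the source may have more. Where it says the series, first, only, none or still open, it means among the compounds named here.

Compound 1 `O=c1cc(-c2ccccc2)oc2cc(O)c(OCCCN3CCCCC3)c(O)c12` gives 70600 nM
Compound 2 `O=c1cc(-c2ccccc2)oc2cc(OCc3ccccc3)c(OCCCN3CCCCC3)c(O)c12` gives 2200 nM
Compound 3 `O=c1cc(-c2ccccc2)oc2cc(O)c(OCCCCN3CCCC3)c(O)c12` gives > 100000 nM as a limit

In a functional assay on HepG2 cells (Homo sapiens) for antiproliferative activity, read by MTT assay, with a stated time of 48 h (on this read-out lower numbers stand for stronger inhibition and higher numbers for weaker inhibition), compound 2 gives 2200 nM as the lowest of the numbers shown. Compound 4 `CCN(CC)CCCCOc1c(OCc2ccccc2)cc2oc(-c3ccccc3)cc(=O)c2c1O` keeps the benzyl of compound 2, a change measured as a 32-fold lower number from compound 1 to compound 2 (1.51 log units; beyond the scatter), and alters only the chain end ((diethylamino)methyl in place of piperidin-1-yl on a saturated chain carbon, three bonds along the chain from an oxygen on an aromatic ring). Within the data shown here, the one measured change at that chain end is an at least 1.4-fold higher number from compound 1 to compound 3 (0.15 log units; that floor lies within the scatter), which rests on a limit and comes from compounds without the benzyl. Among the measured compounds shown here, no large step is therefore expected in this assay, at most a slight rise in the number. The expected step is a 1.4-fold higher number from compound 2 to compound 4 (0.13 log units; within the scatter) as estimated. For compound 4 the estimate is 3000 nM with an expected range from 1100 nM to 8000 nM.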

Compound 4, half-maximal inhibitory concentration: 2200 nM
The estimate for compound 4 lay 1.4-fold (0.13 log units) above the measured number; measured number inside the range.
By their numbers in this assay, from the lowest: compounds 2 and 4 (each within the scatter of the next); then compound 1. At a limit, above all of these: compound 3.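

In this assay, opening the piperidin-1-yl ring to the (diethylamino)methyl end gives no change at the digits printed from compound 2 to compound 4 (within the scatter). Among these compounds, this is the first chain-end step with a number on both sides, and it shows that, with the benzyl in place, the closed ring is not required at this position. The earlier chain-end step rested on compound 3, which gave only a limit: the limit of > 100000 nM in this assay, at which 1 of the 4 values shown sits.

From the compounds shown here alone, whether a morpholine end or a dimethylamino end would fit equally well remains open. So does the effect of the 4-(diethylamino)butyl chain with hydrogen in place of the benzyl.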